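The source may report more compounds than this note shows. Statements on the series, on what has been measured and on what is new or still open speak of the compounds shown alone.

In a functional assay on OCI-Ly3 cells (Homo sapiens) for inhibition, read by CellTiter-Glo, with stated times of 48 h and 96 h (a higher number here means a weaker inhibitor of growth, a lower number a stronger inhibitor of growth), compound 1 `CC(C)[C@@H](C(=O)N1CCC[C@H]1C(=O)N[C@@H](CCCNC(=N)N)C(=O)CF)N(C)C(=O)OCc1ccccc1` gives only a limit, > 20000 nM. Compound 2 `CC(C)[C@H](NC(=O)c1ccc(Br)cc1)C(=O)N1CCC[C@H]1C(=O)N[C@@H](CCCNC(=N)N)C(=O)CF` has the lowest number shown, 130 nM, and compound 3 `CC(C)[C@H](NC(=O)C1CCCCC1)C(=O)N1CCC[C@H]1C(=O)N[C@@H](CCCNC(=N)N)C(=O)CF` gives 940 nM. Compound 4 `N=C(N)NCCC[C@H](NC(=O)[C@@H]1CCCN1C(=O)[C@@H](NC(=O)c1ccc(Br)cc1)C1CCCCC1)C(=O)CF` carries cyclohexyl in place of isopropyl on a saturated chain carbon bound to an amide-type nitrogen and a carbonyl carbon. Among the compounds with values here, no measured step changes this place. The nearest evidence is a 7.2-fold higher number from compound 2 to compound 3 (0.86 log units; beyond the scatter), a modest step with cyclohexyl in place of 4-bromophenyl on a carbonyl carbon, while an at least 150-fold lower number from compound 1 to compound 2 (2.18 log units; beyond the scatter) is large but also lies elsewhere. No step beyond the scatter is therefore expected in this assay, and no direction is favoured. The expected step is a 1.1-fold lower number from compound 2 to compound 4 (0.03 log units; within the scatter). For compound 4 the estimate is 120 nM, with an expected range of 35 nM to 500 nM.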

Compound 4, concentration for 50% growth inhibition: 130 nM
For compound 4 the middle estimate is 1.1-fold (0.03 log units) below the measured one; the measured number falls inside the stated range.
By their numbers in this assay, from the lowest: compounds 2 and 4 (each within the scatter of the next); then compound 3. At a limit, above all of these: compound 1.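

In this assay, cyclohexyl in place of isopropyl on a saturated chain carbon bound to an amide-type nitrogen and a carbonyl carbon gives no change at the digits printed from compound 2 to compound 4 (within the scatter). Within the data shown here, this is the first reading at this place, and it shows that, with 4-bromophenyl on the carbonyl carbon, the larger carbon ring leaves the number within the scatter. Nothing given here explains this result. On these data alone, whether the same holds with the cyclohexyl carbonyl of compound 3 stays open. So does the outcome of an amine, a carboxylic acid or a phenyl ring at this place.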